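Two measured points, one methoxy removal still to test

This account rests on a few compounds, and the source may have more. Where it says the series, first, only, none or still open, it means among the compounds named here.

Two compounds of the series carry a measurement. Compound 1 `COc1ccc(-c2cc(/C=C/C(=O)c3ccc(N)cc3)[nH]n2)cc1` gives -24% in a functional assay on M14 cells (Homo sapiens) for cytotoxicity, read by sulforhodamine B assay, with a stated time of 48 h, tested at 10 uM; on this read-out higher numbers stand for a weaker effect at the one concentration tested and lower numbers for a stronger effect. Compound 2 `COc1cc(-c2cc(/C=C/C(=O)c3ccc(N)cc3)[nH]n2)cc(OC)c1OC` gives -64% in this assay, the lowest of the two numbers; its nearest neighbour is compound 1, whose number stands higher by a gap beyond the usual scatter. Within the data shown here, no single step between measured compounds is available, so the weight of any one change is not known. Compound 3 `COc1ccc(-c2cc(/C=C/C(=O)c3ccc(N)cc3)[nH]n2)cc1OC` is next to be measured in this assay. Relative to compound 2 it differs as follows: hydrogen in place of methoxy on an aromatic carbon. Compound 3 thereby falls between compound 1 and compound 2 in how many methoxy groups it carries. On that ground the step from compound 2 is expected to run upward, towards the number of compound 1, as a number 22 percentage points higher from compound 2 to compound 3 (beyond the scatter). Compound 3 is expected to give about -42% in this assay, within a range from -70% to -8%.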

Compound 3, a percentage reported as activity, at one concentration (the size of the read-out at that concentration, not a potency): -42%
Compound 3: the middle estimate sits on the measured number at the digits printed; low and high end bracket the measured number.
By their numbers in this assay, from the lowest: compound 2; then compound 3; then compound 1.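

Notes on the methoxy series: in this assay the methoxy group ortho to a methoxy group and meta to a large group now has a measured weight from two sides. Its removal gives a number 22 percentage points higher from compound 2 to compound 3 (beyond the scatter), and its addition to the core of compound 1 gives a number 18 percentage points lower from compound 1 to compound 3 (beyond the scatter), so each single change lies beyond the scatter, whereas the earlier pair differed in two places. Across these three compounds, the number falls as methoxy groups are added, and none of the three goes against this, though the data give no reason for the trend.

Still open, as far as these compounds go, is whether this position needs a methoxy group at all, or whether a hydroxyl group, an ethoxy group or a fluorine atom there would give a comparable number. The compounds shown also leave open whether the same steps would hold with the shared core changed elsewhere.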